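A few compounds are considered here, and "the series" means these few. Any claim that something is new, unique, unknown or untested is made for them only; others in the source may bear on it.

Measured compounds in a functional assay on CCRF-CEM cells (Homo sapiens) for cytotoxicity, with a stated time of 72 h; on this read-out higher numbers stand for weaker inhibition and lower numbers for stronger inhibition:
compound 1 `CN(C)c1ccc(/C=C2\CCC/C(=C\c3ccccc3[N+](=O)[O-])C2=O)cc1`: 168000 nM
compound 2 `O=C1CCCC/C1=C\c1cccc([N+](=O)[O-])c1`: 8120 nM

Among the compounds with values here, two numbers so far. Compound 1 stands highest of the two; in this assay compound 1 gives 168000 nM. Compound 2 gives 8120 nM, and the gap between the two values lies beyond the scatter. Within the data shown here, no step between these two is worked out, since the two structures differ in more than one place; the pair shows only that compound 2 sits far lower.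

Compound 3 `O=C1/C(=C/c2ccc(F)cc2)CCC/C1=C\c1ccccc1[N+](=O)[O-]` is not yet measured. It differs from compound 1 in one place: fluoro in place of dimethylamino on an aromatic carbon. Nothing measured bears directly on this change. The expectation for compound 3 is a modest shift toward a lower number, with a step of a 2.8-fold lower number from compound 1 to compound 3 (0.45 log units; beyond the scatter) that may not exceed the scatter. Compound 3 is estimated at 60000 nM, range 15000 nM to 200000 nM.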

Compound 3, half-maximal inhibitory concentration: 1510 nM
For compound 3 the middle estimate is 40-fold (1.60 log units) above the measured one; the measured number lies below the stated range.
By their numbers in this assay, from the lowest: compound 3; then compound 2; then compound 1.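

In this assay, within the data shown here, this is the first comparison with a single change, and it shows that the group on this aromatic carbon strongly affects the read-out. Fluoro in place of dimethylamino gives a 110-fold lower number from compound 1 to compound 3 (2.05 log units; beyond the scatter), a large step beyond the scatter, with the rest of the core of compound 1 unchanged. Nothing available explains the size of this step.

Open, on these data alone, is whether the step comes from the loss of dimethylamino or the arrival of fluoro; a hydrogen, chloro or methoxy in the same place would help separate the two. Also open, as far as these compounds go, is whether a larger amine such as morpholine, or a carboxylic acid, would sit near compound 1 or near compound 3 on this read-out.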